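Removing One Methoxy Group: An Expected Cytotoxicity Value

The source may report more compounds than this note shows. Statements on the series, on what has been measured and on what is new or still open speak of the compounds shown alone.

Measured compounds:
Compound 1, `COc1ccc(-c2cc(/C=C/C(=O)c3ccc(N)cc3)[nH]n2)cc1`, gives 92%.
Compound 2, `COc1ccc(-c2cc(/C=C/C(=O)c3ccc(N)cc3)[nH]n2)cc1OC`, gives 96%.
Compound 3, `COc1cc(C(=O)/C=C/c2cc(-c3cc(OC)c(OC)c(OC)c3)n[nH]2)cc(OC)c1OC`, gives 92%.

All three values come from a functional assay on SNB-19 cells (Homo sapiens) for cytotoxicity, read by sulforhodamine B assay, with a stated time of 48 h, tested at 0.01 uM; a higher number here means a weaker effect of the compound at the concentration tested, a lower number a stronger effect. Compound 1 and compound 2 share one core and differ in a single spot, (hydrogen in place of methoxy on an aromatic carbon). That change made a small step, a number 4 percentage points lower from compound 2 to compound 1 (within the scatter), so the two compounds look alike in this assay. Compound 3 has a different core; how the core of compound 3 and the core of compound 2 differ is not broken down here. Compound 3 sits level with compound 1 at the digits given, and the gap to compound 2 is within the scatter.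

Compound 4, `COc1ccc(-c2cc(/C=C/C(=O)c3cc(OC)c(OC)c(OC)c3)[nH]n2)cc1OC`, has not yet been measured. It arises from compound 3 by hydrogen in place of methoxy on an aromatic carbon. This is the same kind of change as that from compound 2 to compound 1, although here the spot is also meta to a methoxy group. Because the earlier change gave only a number 4 percentage points lower from compound 2 to compound 1 (within the scatter), a step of similar small size is expected, a number 2 percentage points lower from compound 3 to compound 4 (within the scatter). Compound 4 is therefore estimated to give 90%, expected between 80% and 100%.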

Compound 4, a percentage reported as activity, at one concentration (the size of the read-out at that concentration, not a potency): 91%
Compound 4: the middle estimate sits 1 percentage points below what was measured; the range from low to high includes it.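

Replacing a methoxy group with hydrogen on the core of compound 3 gave only a small step in this assay (a number 1 percentage points lower from compound 3 to compound 4 (within the scatter)). Set beside the earlier example, the change reads alike on the two cores: the same change on two cores in this assay, a number 4 percentage points lower (within the scatter) from compound 2 to compound 1 and a number 1 percentage points lower (within the scatter) from compound 3 to compound 4, 3 percentage points apart, within the scatter of two such steps. This does not establish a general rule, since it rests on two pairs of compounds, one cell line and one tested concentration, and it does not show that a methoxy group at any other spot or on any other core could be removed with an equally small step.

The compounds shown carry only hydrogen or methoxy at the changed spot, leaving open what a hydroxyl group, a fluorine atom or a longer chain such as ethoxy would give there. Also open, going by these compounds, is whether the step would stay this small at a higher concentration than the one used in this assay.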